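Trifluoromethyl to 4-ethylpiperazin-1-yl on the aromatic ring

The source may report more compounds than this note shows. Statements on the series, on what has been measured and on what is new or still open speak of the compounds shown alone.

In a functional assay on K562 cells (Homo sapiens) for inhibition, read by MTT assay, with a stated time of 48 h (on this read-out higher numbers stand for weaker inhibition and lower numbers for stronger inhibition), compound 1 `Nc1n[nH]c2cc(-c3cn([C@@H]4CN[C@H](C(=O)Nc5ccc(Cl)c(C(F)(F)F)c5)C4)nn3)ccc12` gives 8320 nM, and compound 2 `CC(=O)Nc1n[nH]c2cc(-c3cn([C@@H]4CN[C@H](C(=O)Nc5ccc(Cl)c(C(F)(F)F)c5)C4)nn3)ccc12` gives 15500 nM. Within the data shown here, the only measured step, a 1.9-fold higher number from compound 1 to compound 2 (0.27 log units; within the scatter), stays within the scatter and leaves the pair level. Compound 3 `CCN1CCN(c2cc(NC(=O)[C@@H]3C[C@H](n4cc(-c5ccc6c(N)n[nH]c6c5)nn4)CN3)ccc2Cl)CC1` carries 4-ethylpiperazin-1-yl in place of trifluoromethyl on an aromatic carbon, ortho to a chloro group: 4-ethylpiperazin-1-yl in place of trifluoromethyl on an aromatic carbon. The measured step lies at another place on the molecule and offers little guide, so only a modest move toward a lower number is expected in this assay. The expected step is a 1.8-fold lower number from compound 1 to compound 3 (0.27 log units; within the scatter). For compound 3 the estimate is 4500 nM, ranging from 1200 nM to 15000 nM.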

Compound 3, half-maximal inhibitory concentration: 180 nM
Compound 3: middle estimate off by 25-fold (1.40 log units), on the high side; the measured number lies below the stated range.
By their numbers in this assay, from the lowest: compound 3; then compounds 1 and 2 (each within the scatter of the next).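

In this assay, among these compounds, this aromatic carbon, ortho to a chloro group, is the first place where a change moves the number beyond the scatter: 4-ethylpiperazin-1-yl in place of trifluoromethyl gives a 46-fold lower number from compound 1 to compound 3 (1.66 log units; beyond the scatter) and sets compound 3 apart from both earlier compounds. The acetyl step on the shared core gave no such separation. Nothing available explains the size of this step.

Going by these compounds, whether the step belongs to the piperazine ring or to its ethyl chain stays open. So does what a morpholin-4-yl group or a plain amine on this carbon would give.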